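Methoxy moved around the benzylamine ring

The source may report more compounds than this note shows. Statements on the series, on what has been measured and on what is new or still open speak of the compounds shown alone.

Measured compounds in a functional assay on MIA PaCa-2 cells (Homo sapiens) for inhibition, read by MTT assay, with a stated time of 72 h; a lower number here means a stronger inhibitor of growth, a higher number a weaker inhibitor of growth:
compound 1 `CN(CCCNS(=O)(=O)c1cc(C(F)(F)F)cc(C(F)(F)F)c1)Cc1ccccc1` gives 33000 nM
compound 2 `O=S(=O)(NCCCNCc1ccccc1)c1cc(C(F)(F)F)cc(C(F)(F)F)c1` gives 11000 nM
compound 3 `COc1ccc(CNCCCNS(=O)(=O)c2cc(C(F)(F)F)cc(C(F)(F)F)c2)cc1` gives 2500 nM

Compound 3 stands lowest of the three numbers in this assay. Its nearest neighbour is compound 2, the step being a 4.4-fold lower number from compound 2 to compound 3 (0.64 log units; beyond the scatter); the furthest is compound 1, with a 13-fold lower number from compound 1 to compound 3 (1.12 log units; beyond the scatter). Part of that larger gap comes from the first step, a 3.0-fold lower number from compound 1 to compound 2 (0.48 log units; beyond the scatter), and the rest from the methoxy.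

Compound 4 `COc1cccc(CNCCCNS(=O)(=O)c2cc(C(F)(F)F)cc(C(F)(F)F)c2)c1` differs from compound 3 by 3-methoxyphenyl in place of 4-methoxyphenyl on a saturated chain carbon bound to an amine nitrogen. Within the data shown here, the only measured step that touches this part of the molecule is a 4.4-fold lower number from compound 2 to compound 3 (0.64 log units; beyond the scatter), where placing the methoxy on the ring brought a modest gain. Among the measured compounds shown here, no measured pair shows the same group moved to another ring carbon, so the size of the present step cannot be read from the series directly. Since the group itself is kept, a large loss seems unlikely; a step within the scatter or modestly beyond it, more probably toward a higher number than a lower one, is the working expectation in this assay.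

For compound 4 in this assay the estimated value is 4000 nM, with a range from 1500 nM to 12000 nM. The expected step from compound 3 to compound 4 is therefore a 1.6-fold higher number from compound 3 to compound 4 (0.20 log units; within the scatter).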

Compound 4, concentration for 50% growth inhibition: 3400 nM
Compound 4: middle estimate off by 1.2-fold (0.07 log units), on the high side; low and high end bracket the measured number.
By their numbers in this assay, from the lowest: compounds 3 and 4 (each within the scatter of the next); then compound 2; then compound 1.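

In this assay, the change from 4-methoxyphenyl to 3-methoxyphenyl on the saturated chain carbon bound to the amine nitrogen stays within the scatter (a 1.4-fold higher number from compound 3 to compound 4 (0.13 log units; within the scatter)), so this assay does not separate these two placements of the methoxy. The gain from adding a methoxy to the ring of compound 2 therefore appears with either placement, and the step to the 3-methoxyphenyl compound is modest and beyond the scatter (a 3.2-fold lower number from compound 2 to compound 4 (0.51 log units; beyond the scatter)), while the wider change from the tertiary benzyl(methyl)amino compound, which removes the methyl and adds the methoxy together, is also modest and beyond the scatter (a 9.7-fold lower number from compound 1 to compound 4 (0.99 log units; beyond the scatter)). Nothing at hand explains why the two placements read alike.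

The compounds shown leave open whether another ring substituent, such as a fluorine, a hydroxyl or a dimethylamino group, would read differently from methoxy at these places. They also leave open whether the methoxy gain would persist with the methyl kept on the amine nitrogen, or with a longer chain in place of the present one.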